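The source may report more compounds than this note shows. Statements on the series, on what has been measured and on what is new or still open speak of the compounds shown alone.

Working notes on a set of compounds built on a shared core. Compound 1 `Cn1ncc2c(-c3ccc(F)cc3)cc(NNC(=O)Nc3cc(Cl)cc(Cl)c3)nc21`, compound 2 `CCN(CC)c1cc(NC(=O)NNc2cc(-c3ccc(F)cc3)c3cnn(C)c3n2)cc(Cl)n1` and compound 3 `COc1ccc(-c2cc(NNC(=O)Nc3cc(Cl)nc(Cl)c3)nc3c2c(C)nn3C)cc1` have been run in a functional assay on HCT-116 cells (Homo sapiens) for cytotoxicity, read by MTT assay, with a stated time of 48 h, in the presence of a further agent that is not named here; on this read-out lower numbers stand for an effect already at smaller amounts and higher numbers for an effect only at larger amounts of compound. In this assay compound 1 gives 39100 nM, compound 2 gives 29400 nM and compound 3 gives 82300 nM. Compound 2 holds the lowest of the three numbers; its gap to compound 1 lies within the usual scatter, so no order between those two is claimed, whereas its gap to compound 3 lies beyond the scatter.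

Compound 4 `COc1cc(NC(=O)NNc2cc(-c3ccc(F)cc3)c3cnn(C)c3n2)cc(Cl)n1` has not yet been measured. It differs from compound 2 in one place: methoxy in place of diethylamino on an aromatic carbon. Within the data shown here, no measured pair in the set changes this position, so the size of the step from compound 2 to compound 4 in this assay cannot be read from any measured pair. The step of a 1.4-fold higher number from compound 2 to compound 4 (0.13 log units; within the scatter) is expected to be small, with no direction favoured beyond the scatter. Compound 4 is therefore estimated at 40000 nM, within a range of 15000 nM to 100000 nM.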

Compound 4, half-maximal effective concentration: 75300 nM
For compound 4 the middle estimate is 1.9-fold (0.27 log units) below the measured one; measured number inside the range.
By their numbers in this assay, from the lowest: compounds 2, 1, 4 and 3 (each within the scatter of the next, the first and the last beyond it).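

The step of a 2.6-fold higher number from compound 2 to compound 4 (0.41 log units; beyond the scatter) in this assay gives this position its first measured change: methoxy in place of diethylamino, on the aromatic carbon next to the ring nitrogen, moves the number beyond the scatter, so the group at this place matters to the read-out. The step of a 1.9-fold higher number from compound 1 to compound 4 (0.28 log units; within the scatter) in this assay covers a different exchange, 2-chloro-6-methoxypyridin-4-yl in place of 3,5-dichlorophenyl on an amide-type nitrogen, and shows no change that can be separated from the scatter. Nothing at hand bears on the reason for either step.

As far as these compounds go, how a dimethylamino group, a morpholine or a primary amine would read at this position remains open. With a single change here, the data also cannot tell whether the amine nitrogen or the ethyl chains of diethylamino account for the step.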